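The source may hold more compounds than are shown below. What is called first, only, known or untested is meant among the compounds shown, and "the series" means these compounds.

Three amides on one shared core carry the series in a functional assay on BXPC-3 cells (Homo sapiens) for antiproliferative activity, read by MTT assay, with a stated time of 24 h; on this read-out lower numbers stand for stronger inhibition and higher numbers for weaker inhibition. Compound 1 `CCn1c(C(=O)N[C@H](C)C(=O)OC)ccc1C(CC)(CC)c1ccc(OCS(=O)(=O)c2ccccc2)c(C)c1` gives only a limit, > 50000 nM. Compound 2 `CCn1c(C(=O)N[C@@H](CO)C(C)C)ccc1C(CC)(CC)c1ccc(OCS(=O)(=O)c2ccccc2)c(C)c1` gives 13200 nM. Compound 3 `CCn1c(C(=O)NCCCO)ccc1C(CC)(CC)c1ccc(OCS(=O)(=O)c2ccccc2)c(C)c1` gives 26600 nM. Of the two real numbers, compound 3 holds the higher, though its step from compound 2, a 2.0-fold higher number from compound 2 to compound 3 (0.30 log units; within the scatter), sits within the scatter. The third value shown is a limit, (the limit of > 50000 nM in this assay, at which 1 of the 3 values shown sits). The steps from compound 1, an at least 3.7-fold lower number from compound 1 to compound 2 (0.57 log units; beyond the scatter) and an at least 1.8-fold lower number from compound 1 to compound 3 (0.27 log units; that floor lies within the scatter), both lead to hydroxyl-bearing amide substituents and are floors rather than firm numbers.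

Compound 4 `CCn1c(C(=O)N[C@@H](CCC(=O)O)C(=O)O)ccc1C(CC)(CC)c1ccc(OCS(=O)(=O)c2ccccc2)c(C)c1` is the next member: 1,3-dicarboxypropyl in place of 3-hydroxypropyl on an amide-type nitrogen. Going by the values given here, no measured step exchanges a hydroxyl chain for carboxylic acids, so none bears on it directly; the nearest point of comparison is the ester-bearing compound 1, whose value is a limit. Within the hydroxyl-bearing pair the exchange gave only a 2.0-fold higher number from compound 2 to compound 3 (0.30 log units; within the scatter). The expected step is therefore a 1.5-fold higher number from compound 3 to compound 4 (0.18 log units; within the scatter), small or toward a higher number, with a real chance that the assay again returns a limit. Compound 4 is expected to give about 40000 nM, with a range from 15000 nM to 120000 nM.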

Compound 4, half-maximal inhibitory concentration: > 50000 nM
Compound 4 was reported as a limit; the forecaster's own chance of this, stated with the estimate: 45%; middle value at least 1.2-fold (0.09 log units) from the limit.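

In this assay compound 4 gives > 50000 nM, which is a limit and not a number. On the amide-type nitrogen, 1,3-dicarboxypropyl now gives a firm loss against the branched hydroxyl substituent, an at least 3.7-fold higher number from compound 2 to compound 4 (0.57 log units; beyond the scatter), while the comparison with the straight hydroxyl chain, an at least 1.8-fold higher number from compound 3 to compound 4 (0.27 log units; that floor lies within the scatter), has a floor that still lies within the scatter, so the new substituent is separated clearly from only one of the two hydroxyl-bearing amides. The ester-bearing compound 1 and the diacid compound 4 cannot be ranked, since the step between them cannot be read with a limit on both sides: the limit of > 50000 nM in this assay, at which 2 of the 4 values shown sit.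

As far as these compounds go, how far the number for compound 4 really lies from those of compound 2 and compound 3 remains open, and so does the question of whether one carboxylic acid on the chain would behave as the two of compound 4 do. An amine at the end of the chain, or a longer hydroxyalkyl chain, would show whether any substituent at this nitrogen moves the number beyond the scatter in the stronger direction from compound 2.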